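The source may hold more compounds than are shown below. What is called first, only, known or untested is meant among the compounds shown, and "the series" means these compounds.

Values in an ADME assay on HepG2 cells (Homo sapiens) for cytotoxicity, read by MTT assay, with a stated time of 24 h (on this read-out higher numbers stand for lower toxicity in this test and lower numbers for higher toxicity in this test), each one a limit:
- compound 1 `CC1Cn2c(nc([N+](=O)[O-])c2-c2ccc(CO)cc2)O1`: > 500000 nM
- compound 2 `CC1Cn2c(nc([N+](=O)[O-])c2-c2ccc(Cl)cc2)O1`: > 140000 nM
- compound 3 `CC1Cn2c(nc([N+](=O)[O-])c2-c2ccccc2)O1`: > 500000 nM

Compound 3 has no number on this read-out, only the limit > 500000 nM. It shares that position with compound 1, as the limit of > 500000 nM in this assay, at which 2 of the 3 values shown sit, shows.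

Compound 4 `CCCOc1ccc(-c2c([N+](=O)[O-])nc3n2CC(C)O3)cc1` carries propoxy in place of hydrogen on an aromatic carbon, para to a large group: propoxy in place of hydrogen on an aromatic carbon.

For the measured compounds named here, three measured steps bear on this change, all swaps on that aromatic carbon: a step that the two limits leave unreadable from compound 1 to compound 3; a step that the two limits leave unreadable from compound 2 to compound 3; a step that the two limits leave unreadable from compound 1 to compound 2. None of them gives a size to carry over. Going by the values given here, the expectation therefore rests on the fact that no compound has reached a measured number in this assay. Compound 2 also stands at a limit, > 140000 nM.

No step beyond the scatter is expected, and any shift would be expected toward lower numbers. The estimated step is an at least 1.6-fold lower number from compound 3 to compound 4 (0.22 log units; that floor lies within the scatter). Compound 4 is expected at 300000 nM, with an estimated range of 80000 nM to 500000 nM.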

Compound 4, half-maximal cytotoxic concentration: > 62500 nM
Compound 4: no number, only a limit; the forecaster's own chance of this, stated with the estimate: 80%; the middle value is on the limit's open side.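

For the compounds shown here, compound 4 gives only a limit in this assay, as do compound 1, compound 2 and compound 3, so no step from any of them to compound 4 can be read. The compounds shown leave open what number any of them would reach on this read-out.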